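A bromo in place of hydrogen: compound 2 to compound 3

This account rests on a few compounds, and the source may have more. Where it says the series, first, only, none or still open, it means among the compounds named here.

Of the compounds shown here, two have been tested in an ADME assay on H9 cells (Homo sapiens) for cytotoxicity, read by XTT assay, with a stated time of 6 days; a lower number here means that less compound is tolerated, a higher number that more compound is tolerated. Compound 1 (`Cc1ccc(Nc2cc(Oc3c(C)cc(Br)cc3C)c([N+](=O)[O-])cc2[N+](=O)[O-])cc1`) gives 53000 nM in this test, a true number that marks where tolerance ends for it.

Compound 2 (`Cc1cccc(C)c1Oc1cc(Nc2ccc(C#N)cc2)c([N+](=O)[O-])cc1[N+](=O)[O-]`) is recorded only as a limit, > 61800 nM. Its standing is therefore (the limit of > 61800 nM in this assay, at which 1 of the 2 values shown sits).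

Compound 3 (`Cc1cc(Br)cc(C)c1Oc1cc(Nc2ccc(C#N)cc2)c([N+](=O)[O-])cc1[N+](=O)[O-]`) has not yet been measured. It departs from compound 2 by a single change, (bromo in place of hydrogen on an aromatic carbon), with the bromo on an aromatic carbon para to a large group and meta to two methyl groups, turning the 2,6-dimethylphenyl into 4-bromo-2,6-dimethylphenyl. Going by the values given here, no measured pair shows this change directly, so the expectation is loose. It leans on compound 1, which carries the same 4-bromo-2,6-dimethylphenyl group and gives 53000 nM. A small fall in tolerated concentration in this assay is expected, an estimated at least 1.3-fold lower number from compound 2 to compound 3 (0.13 log units; that floor lies within the scatter), and it may not exceed the usual scatter. The expected value for compound 3 is 45000 nM. The estimated range for it runs from 15000 nM to 100000 nM.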

Compound 3, half-maximal cytotoxic concentration: > 51700 nM
Compound 3: only a limit was reported (the forecaster's own chance of this, stated with the estimate: 45%); middle value at least 1.1-fold (0.06 log units) away from the limit.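

In this assay compound 3 is recorded only as a limit, > 51700 nM. Neither the step from compound 2 to compound 3 nor the step from compound 1 to compound 3 can be read from this result. The compounds shown leave open where tolerance ends for compound 2 and compound 3, and so what size of change the bromo in place of hydrogen brings.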